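The source may report more compounds than this note shows. Statements on the series, on what has been measured and on what is new or still open speak of the compounds shown alone.

Compound 1 `C=C[C@@](C)(/C=C/c1ccc(OC)cc1)CCC=C(C)C` is tested in a functional assay on HepG2 cells (Homo sapiens) for cytotoxicity, with a stated time of 72 h (on this read-out higher numbers stand for an effect only at larger amounts of compound and lower numbers for an effect already at smaller amounts), and stands at the edge of what that read-out can report. Compound 1 gives > 52000 nM as a limit of the assay and not as a number. Compound 2 `C=C[C@@](C)(/C=C/c1ccc(O)cc1)CC/C=C/C(=O)c1ccccc1` gives > 52000 nM as a limit too. Compound 3 `CCOC(=O)/C(C)=C/c1cc(/C=C/[C@](C)(/C=C/c2ccc(OC)cc2)CCC=C(C)C)ccc1O` gives > 52000 nM as a limit as well. The series thus rests on the limit of > 52000 nM in this assay, at which 3 of the 3 values shown sit, and on no true number. No two of these compounds differ in only one place, so the data offer no measured step to go by.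

Compound 4 `C=C[C@@](C)(/C=C/c1ccc(Nc2ccccc2)cc1)CCC=C(C)C` keeps the core of compound 1 and changes one site, with anilino in place of methoxy on an aromatic carbon, para to a large group anilino in place of methoxy on an aromatic carbon as the counted difference. The expectation starts from compound 1 with its limit of > 52000 nM and allows only a modest move toward smaller amounts, or none beyond the scatter. The expected step of an at least 1.2-fold lower number from compound 1 to compound 4 (0.09 log units; that floor lies within the scatter) is therefore small, and the assay may again report only a limit. For compound 4 the estimated value is 42000 nM with an expected range from 15000 nM to 52000 nM in this estimate.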

Compound 4, half-maximal effective concentration: > 52000 nM
Compound 4: only a limit was reported; the forecaster's own chance of this, stated with the estimate: 60%; at least 1.2-fold (0.09 log units) between middle value and limit.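

In this assay compound 4 gives > 52000 nM, a limit of the assay and not a number. Compound 1 also stands at a limit, so no step can be read for anilino in place of methoxy, and the series still rests on one figure: the limit of > 52000 nM in this assay, at which 4 of the 4 values shown sit. The compounds shown leave open whether any of them would give a true number in this assay.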